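The source may report more compounds than this note shows. Statements on the series, on what has been measured and on what is new or still open speak of the compounds shown alone.

Measured compounds:
- Compound 1, `Cc1ccc(-c2cc(C(=O)N3CCC4(CC3)CC(=O)c3nn(C(C)(C)C)cc3O4)c3ccccc3n2)cc1`: 1440 nM
- Compound 2, `Cc1ccccc1-c1cc(C(=O)N2CCC3(CC2)CC(=O)c2nn(C(C)(C)C)cc2O3)c2ccccc2n1`: value at the assay limit, given below
- Compound 3, `Cc1cc(C(=O)N2CCC3(CC2)CC(=O)c2nn(C(C)(C)C)cc2O3)c2ccccc2n1`: 9480 nM

In a functional assay on HepG2 cells (Homo sapiens) for inhibition, read by MTT assay, with a stated time of 72 h (a higher number here means a weaker inhibitor, a lower number a stronger inhibitor), compound 1 gives the lowest number of the two numbers shown, with compound 3 its nearest neighbour. Compound 2 reaches only the limit of this assay, namely > 10000 nM, and this is a limit, not a number (the limit of > 10000 nM in this assay, at which 1 of the 3 values shown sits). Compound 4, `CCOc1cc(C(=O)N2CCC3(CC2)CC(=O)c2nn(C(C)(C)C)cc2O3)c2ccccc2n1`, differs from compound 1 in one place: ethoxy in place of 4-methylphenyl on an aromatic carbon. The step most like this one is the swap of the same 4-methylphenyl for a small methyl, which gave a 6.6-fold higher number from compound 1 to compound 3 (0.82 log units; beyond the scatter); the move to a 2-methylphenyl gave an at least 6.9-fold higher number from compound 1 to compound 2 (0.84 log units; beyond the scatter). A small ethoxy in place of the 4-methylphenyl is therefore expected to give a step of similar size and direction, estimated as a 5.6-fold higher number from compound 1 to compound 4 (0.74 log units; beyond the scatter). Compound 4 is thus expected to give about 8000 nM, in the range 3000 nM to 20000 nM.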

Compound 4, half-maximal inhibitory concentration: > 10000 nM
Compound 4 gave a limit, no number (the forecaster's own chance of this, stated with the estimate: 35%); middle value at least 1.2-fold (0.09 log units) from the limit.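

Ethoxy in place of 4-methylphenyl gives an at least 6.9-fold higher number from compound 1 to compound 4 (0.84 log units; beyond the scatter) in this assay, so a second small group at this position, this time one holding an oxygen and no ring, also fails to match compound 1. Between the two small groups there is an at least 1.0-fold higher number from compound 3 to compound 4 (0.02 log units; that floor lies within the scatter), so no real difference between methyl and ethoxy can be read. Compound 2 and compound 4 each stand at a limit and not at a number, so the step between them cannot be read: the limit of > 10000 nM in this assay, at which 2 of the 4 values shown sit.

From the compounds shown here alone, it remains open whether an amine or a longer chain such as butoxy at this position would bring the number back towards that of compound 1.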